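The source may report more compounds than this note shows. Statements on the series, on what has been measured and on what is new or still open speak of the compounds shown alone.

Compound 1 `O=C(NS(=O)(=O)c1ccc(F)cc1)c1ccc(Nc2nc(NC3(c4ccc(Cl)cc4)CC3)nc(OCC(F)(F)F)n2)cc1` in an ADME assay on microsomes from liver (Rattus norvegicus) for metabolic stability, with a stated time of 10 min (on this read-out higher numbers stand for a more stable compound and lower numbers for a less stable compound), gives 99%; compound 2 `O=C(NS(=O)(=O)c1ccccc1)c1ccc(Nc2nc(NC3(c4ccc(Cl)cc4)CC3)nc(OCC(F)(F)F)n2)cc1` gives 100% and compound 3 `O=C(NS(=O)(=O)CCNCc1ccccc1)c1ccc(Nc2nc(NC3(c4ccc(Cl)cc4)CC3)nc(OCC(F)(F)F)n2)cc1` gives 100%, so compound 1 stands within the scatter of both, all three near the top of the read-out. The step to compound 4 `NCCS(=O)(=O)NC(=O)c1ccc(Nc2nc(NC3(c4ccc(Cl)cc4)CC3)nc(OCC(F)(F)F)n2)cc1` is 2-aminoethyl in place of 4-fluorophenyl on a sulfonyl sulfur. The measured step that bears most on it is a number 1 percentage points higher from compound 1 to compound 3 (within the scatter), where a 2-(benzylamino)ethyl replaced the 4-fluorophenyl on the sulfonyl sulfur; no change at the digits printed from compound 2 to compound 3 (within the scatter) points the same way. On that basis no movement beyond the scatter is expected for compound 4, the expected step being a number 2 percentage points lower from compound 1 to compound 4 (within the scatter). Compound 4 is therefore estimated at 97%, with a range from 85% to 100%.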

Compound 4, percent of the compound remaining: 100%
Compound 4: middle estimate off by 3 percentage points, on the low side; low and high end bracket the measured number.
By their numbers in this assay, from the lowest: compounds 1, 2, 3 and 4 (each within the scatter of the next).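

Replacing the aryl group on the sulfonyl sulfur with the short 2-aminoethyl chain leaves the read-out in this assay within the scatter (a number 1 percentage points higher from compound 1 to compound 4 (within the scatter); no change at the digits printed from compound 2 to compound 4 (within the scatter)). Hydrogen in place of benzyl on the amine nitrogen also stays within the scatter (no change at the digits printed from compound 3 to compound 4 (within the scatter)), so the terminal benzyl group is not needed to hold this read-out among these compounds. Nothing available explains these results.

All four values lie near the top of this assay, which leaves little room to separate further changes at this position. A carboxylic acid, a dimethylamino group or a longer aminoalkyl chain on the sulfonyl sulfur remains an open case.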